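A Methylamino in Place of a Methoxy on the Carbonyl

The compounds below may be only part of what the source reports. "The series", "measured", "known", "first", "only" and "open" are said of these compounds alone.

Three compounds share one core and differ only in the group carried on a chain carbon bound to an aromatic carbon. In a functional assay for agonist activity at follicle-stimulating hormone receptor (Homo sapiens), read by a luciferase reporter (on this read-out higher numbers stand for an effect only at larger amounts of compound and lower numbers for an effect already at smaller amounts), compound 1 `CCCCCCCCN1C(=O)[C@H](Cc2ccc(-c3cccc(CN(CCCC)C(C)=O)c3)cc2)N(C)C(=O)[C@@H]1C` gives 14 nM. Compound 2 `CCCCCCCCN1C(=O)[C@H](Cc2ccc(-c3cccc(CN(COC)C(C)=O)c3)cc2)N(C)C(=O)[C@@H]1C` gives 9.7 nM in this assay, and the change between them, a 1.4-fold lower number from compound 1 to compound 2 (0.16 log units; within the scatter), is small. Compound 3 `CCCCCCCCN1C(=O)[C@H](Cc2ccc(-c3cccc(CN(COC)C(=O)OC)c3)cc2)N(C)C(=O)[C@@H]1C` gives 1.8 nM and stands as the most potent of the three, since both a 7.8-fold lower number from compound 1 to compound 3 (0.89 log units; beyond the scatter) and a 5.4-fold lower number from compound 2 to compound 3 (0.73 log units; beyond the scatter) lie beyond the scatter.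

Compound 4 `CCCCCCCCN1C(=O)[C@H](Cc2ccc(-c3cccc(CN(COC)C(=O)NC)c3)cc2)N(C)C(=O)[C@@H]1C` differs from compound 3 by methylamino in place of methoxy on a carbonyl carbon. Going by the values given here, the only measured step at this same carbonyl carbon is a 5.4-fold lower number from compound 2 to compound 3 (0.73 log units; beyond the scatter), which swapped a methyl for a methoxy and moved the number modestly; no measured step tests a methylamino there. That step shows the carbonyl substituent can shift the value, but it gives no direction for this particular exchange. A small step is therefore expected, quite possibly within the scatter, with a slight lean toward a higher number, so compound 4 is estimated at 3 nM with a range from 1 nM to 9 nM, meaning an expected step of a 1.7-fold higher number from compound 3 to compound 4 (0.22 log units; within the scatter).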

Compound 4, half-maximal effective concentration: 3.6 nM
Beside the measured number, compound 4's estimate is 1.2-fold (0.08 log units) below it; measured number inside the range.
By their numbers in this assay, from the lowest: compounds 3 and 4 (each within the scatter of the next); then compounds 2 and 1 (each within the scatter of the next).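

In this assay the exchange of methoxy for methylamino on this carbonyl carbon brings in a hydrogen-bond donor and takes out a hydrogen-bond acceptor, yet a 2.0-fold higher number from compound 3 to compound 4 (0.30 log units; within the scatter) leaves the two compounds unseparated. Set against the methyl on the same carbon, methylamino still gives a 2.7-fold lower number from compound 2 to compound 4 (0.43 log units; beyond the scatter), so the gain seen with methoxy is not tied to methoxy alone: two different groups on this carbonyl carbon now stand apart from methyl. Over the whole group on the chain carbon, (methoxymethyl)(methylcarbamoyl)amino in place of acetyl(butyl)amino gives a 3.9-fold lower number from compound 1 to compound 4 (0.59 log units; beyond the scatter), which shows that this urea-type arrangement also holds a gain beyond the scatter over the starting group.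

The data at hand offer no explanation for why methyl stands apart from the other two groups. Still open, on these data alone, is whether dimethylamino or ethylamino on this carbonyl carbon would stay with methoxy and methylamino or fall back toward methyl, and whether methylamino would act the same way with a butyl chain in place of the methoxymethyl.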